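Methyl in Place of Methoxy on the Anilide of Compound 2

The source may hold more compounds than are shown below. What is called first, only, known or untested is meant among the compounds shown, and "the series" means these compounds.

Measured compounds:
Compound 1, `COc1ccc(-n2nc(C(N)=O)nc2-c2cc(OC)c(OC)c(OC)c2)cc1`: 72%
Compound 2, `COc1ccc(-n2nc(C(=O)Nc3ccccc3OC)nc2-c2cc(OC)c(OC)c(OC)c2)cc1`: 30%

Of the compounds shown here, two have been measured in a functional assay on the whole organism for inhibition, with Rattus norvegicus as the target, read by paw edema, with stated times of 30 min and 3 h, at a dose of 0.28 mmol/kg by the oral route; a higher number here means more inhibition at the dose given (going by the name of the read-out), a lower number less inhibition. Compound 1 gives 72%, and compound 2 gives 30%. Going by the values given here, compound 2 thus stands at the lowest of the two numbers, with compound 1 as its only neighbour; the one measured step, a number 42 percentage points lower from compound 1 to compound 2 (beyond the scatter), reflects 2-methoxyphenyl in place of hydrogen on an amide-type nitrogen, a change of a different kind from the one considered next.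

Compound 3, `COc1ccc(-n2nc(C(=O)Nc3ccccc3C)nc2-c2cc(OC)c(OC)c(OC)c2)cc1`, differs from compound 2 by methyl in place of methoxy on an aromatic carbon. Among the compounds with values here, no measured step concerns a swap of methyl for methoxy, so the step from compound 1 to compound 2 bears on it only indirectly: it shows that the anilide series sits low in this assay, while giving no direction for the present change. The expected step is therefore a number 2 percentage points higher from compound 2 to compound 3 (within the scatter), no larger than the scatter. Compound 3 is estimated at 32%, with a range from 12% to 55%.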

Compound 3, a percentage reported as inhibition, in the whole organism at one dose (the size of the read-out at that dose, not a potency): 50%
Beside the measured number, compound 3's estimate is 18 percentage points below it, within the range that was stated.
By their numbers in this assay, from the lowest: compound 2; then compound 3; then compound 1.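

In this assay, the group on this aromatic carbon, ortho to a large group, clearly matters: methyl in place of methoxy gives a number 20 percentage points higher from compound 2 to compound 3 (beyond the scatter), so the anilide series is not uniformly low, as compound 2 alone might have suggested. The aryl group on the amide nitrogen still carries a cost, since 2-methylphenyl in place of hydrogen gives a number 22 percentage points lower from compound 1 to compound 3 (beyond the scatter), and this drop is smaller than the one with 2-methoxyphenyl, a number 42 percentage points lower from compound 1 to compound 2 (beyond the scatter). Nothing measured here on these groups accounts for the difference between methyl and methoxy at this place.

Going by these compounds, with only these two groups compared at this place, it remains open whether the gain is specific to methyl or would also appear with a chlorine atom, a hydroxyl or an amine, and whether methyl would give the same result elsewhere on the ring. On these data alone, it is also open whether a small alkyl chain on the amide nitrogen, such as an ethyl group in place of the aryl group, would stay closer to compound 1.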